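A few compounds are considered here, and "the series" means these few. Any claim that something is new, unique, unknown or untested is made for them only; others in the source may bear on it.

Measured compounds:
- Compound 2 `CC(C(=O)NCc1ccc(Cl)cc1)c1ccc(NS(C)(=O)=O)c(F)c1` gives 1060 nM in an assay on CHO cells for displacement of a labelled ligand from transient receptor potential cation channel subfamily V member 1 (Rattus norvegicus); a lower number here means a stronger inhibitor, a higher number a weaker inhibitor.
- Compound 3 `CC(C(=O)NCc1ccc(C2CC2)cc1)c1ccc(NS(C)(=O)=O)c(F)c1` gives 411 nM in this assay.
- Compound 1 `CC(C)(C)c1ccc(CNC(=O)C2(c3ccc(NS(C)(=O)=O)cc3)CC2)cc1` gives 610 nM in this assay.

Among the three, compound 2 gives the highest number; its gap to compound 1 is within the usual scatter, so the two cannot be told apart, while its gap to compound 3 is beyond the scatter. The step from compound 2 to compound 4 `CC(C(=O)NCc1ccc(C2C=CCC2)cc1)c1ccc(NS(C)(=O)=O)c(F)c1` is cyclopent-2-en-1-yl in place of chloro on an aromatic carbon. Among the measured compounds shown here, one measured step bears on it directly: the same chloro was exchanged for a smaller carbon ring, giving a 2.6-fold lower number from compound 2 to compound 3 (0.41 log units; beyond the scatter). The ring entering compound 4 is larger and carries a double bond outside aromatic rings, so the measured step is a guide, not a copy. A step in the same direction, of roughly the same size, is therefore expected. Compound 4 is estimated at 400 nM, within a range from 150 nM to 1100 nM, which means an expected step of a 2.7-fold lower number from compound 2 to compound 4 (0.42 log units; beyond the scatter).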

Compound 4, inhibition constant: 162 nM
Compound 4: middle estimate off by 2.5-fold (0.39 log units), on the high side, within the range that was stated.
By their numbers in this assay, from the lowest: compound 4; then compounds 3, 1 and 2 (each within the scatter of the next, the first and the last beyond it).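

Among the compounds shown here, at this position, on an aromatic carbon para to a large group, the earlier compounds showed only that a small carbon ring could replace chloro, with a 2.6-fold lower number from compound 2 to compound 3 (0.41 log units; beyond the scatter). In this assay, the larger cyclopent-2-en-1-yl goes further, with a 6.5-fold lower number from compound 2 to compound 4 (0.82 log units; beyond the scatter), and the direct comparison of the two rings gives a 2.5-fold lower number from compound 3 to compound 4 (0.40 log units; beyond the scatter), so among these three compounds the number falls as the group grows from chloro to cyclopropyl to cyclopent-2-en-1-yl. No measurement at hand explains why this ring gives the lowest number of the series.

As far as these compounds go, it remains open whether ring size or the double bond accounts for the step, which a saturated cyclopentyl group at the same place would help separate. Whether a phenyl ring or a piperidine ring would lower the number further is also unresolved.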